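A few compounds are considered here, and "the series" means these few. Any claim that something is new, unique, unknown or untested is made for them only; others in the source may bear on it.

Compound 1 `CC(C)(C)c1cc(-c2cc(=O)c3ccc(OCC(=O)O)cc3o2)cc(C(C)(C)C)c1O`: 3000 nM; 100 nM (2 entries)
Compound 2 `CC(C)(C)c1cc(-c2cc(=O)c3ccccc3o2)cc(C(C)(C)C)c1O`: 3000 nM
Compound 3 `CCCCCOC(=O)COc1ccc2c(=O)cc(-c3cc(C(C)(C)C)c(O)c(C(C)(C)C)c3)oc2c1`: not yet measured

For the measured compounds named here, in a functional assay for inhibition (a lower number here means a stronger inhibitor, a higher number a weaker inhibitor), compound 2 stands at 3000 nM, its only number, and a further entry gives no single number. Compound 3 differs from it in one place, with (pentyloxycarbonyl)methoxy in place of hydrogen on an aromatic carbon. Going by the values given here, no measured step shows what this change does. The nearest guide is loose, as compound 1 gives 3000 nM; 100 nM (2 entries), and those entries disagree: the several entries of compound 1 in this assay, 3000 nM; 100 nM (2 entries). A moderate shift toward stronger inhibition is therefore expected, and the expected step is a 3.0-fold lower number from compound 2 to compound 3 (0.48 log units; beyond the scatter). For compound 3 the estimated value is 1000 nM, with an expected range of 150 nM to 6000 nM.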

Compound 3, half-maximal inhibitory concentration: 5000 nM
Beside the measured number, compound 3's estimate is 5.0-fold (0.70 log units) below it; the measured number falls inside the stated range.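

In this assay, placing (pentyloxycarbonyl)methoxy in place of hydrogen on an aromatic carbon gives a 1.7-fold higher number from compound 2 to compound 3 (0.22 log units; within the scatter). This position of the shared core therefore accepts this long ester chain with no measurable gain or loss in inhibition, and the ester does not reach the lower of the two numbers recorded for compound 1.

An amine or an amide at this position could show whether any group here moves the number. Whether the carboxylic acid of compound 1 differs from the ester of compound 3 stays unsettled, as its entries disagree: the several entries of compound 1 in this assay, 3000 nM; 100 nM (2 entries)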